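This account rests on a few compounds, and the source may have more. Where it says the series, first, only, none or still open, it means among the compounds named here.

Measured in an in vivo ADME assay on the whole organism (strain Sprague-Dawley) for pharmacokinetics, with Rattus norvegicus as the target; a higher number here means that a larger share of the oral dose reaches the circulation, a lower number that a smaller share of the oral dose reaches the circulation:
- compound 1 `CN[C@@H](C)c1ccc(N2CC[C@H](NS(=O)(=O)c3ccc4cc(Cl)ccc4c3)C2=O)c(F)c1`: > 10% (a limit, not a number)
- compound 2 `CN(C)[C@H]1CCc2cc(N3CC[C@H](NS(=O)(=O)c4ccc5cc(Cl)ccc5c4)C3=O)ccc21`: 61%
- compound 3 `CNC1CCc2cc(N3CC[C@H](NS(=O)(=O)c4ccc5cc(Cl)ccc5c4)C3=O)ccc21`: 25%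

Compound 1 has only a limit in this assay, namely > 10%. Compound 4 `O=C1[C@@H](NS(=O)(=O)c2ccc3cc(Cl)ccc3c2)CCN1c1ccc([C@H]2CCCN2)cc1F` carries pyrrolidin-2-yl in place of 1-(methylamino)ethyl on an aromatic carbon. Among the compounds with values here, no measured step covers this change. Compound 3 gives 25% and compound 2 gives 61%, and neither differs from compound 1 in one place alone, so they offer only loose guidance. No change beyond the usual scatter is expected, and the estimated step is a step that the limit leaves unreadable from compound 1 to compound 4. For compound 4 the expected value is 20%, with an estimated range of 6% to 45%.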

Compound 4, oral bioavailability: 25%
Estimate against measurement, compound 4: 5 percentage points below, within the range that was stated.
By their numbers in this assay, from the lowest: compounds 3 and 4 (each within the scatter of the next); then compound 2.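

The step from compound 1 to compound 4 in this assay cannot be read, because compound 1 carries only a limit: the limit of > 10% in this assay, at which 1 of the 4 values shown sits.

Left open in this assay is the size of the change from 1-(methylamino)ethyl to pyrrolidin-2-yl on the shared core.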